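Aryl variation on the chain carbon: compound 3 to compound 4

The source may report more compounds than this note shows. Statements on the series, on what has been measured and on what is new or still open speak of the compounds shown alone.

In a functional assay on DU-145 cells (Homo sapiens) for inhibition, read by trypan blue exclusion, with a stated time of 96 h (a lower number here means a stronger inhibitor of growth, a higher number a weaker inhibitor of growth), compound 1 `O=C(/C(=C\c1ccc(F)cc1F)S(=O)(=O)c1ccc(Br)cc1)c1ccc(Br)cc1` gives 7500 nM, compound 2 `O=C(/C(=C\c1ccc(Br)cc1)S(=O)(=O)c1ccc(Br)cc1)c1ccc(Br)cc1` gives 10000 nM, and compound 3 `COc1ccc(/C=C(\C(=O)c2ccc(Br)cc2)S(=O)(=O)c2ccc(Br)cc2)c(F)c1` gives 10000 nM. Compound 3 stands level with compound 2, the two together the highest numbers of the three, and compound 1 lies within the scatter of both: a 1.3-fold higher number from compound 1 to compound 2 (0.12 log units; within the scatter), a 1.3-fold higher number from compound 1 to compound 3 (0.12 log units; within the scatter), no change at the digits printed from compound 2 to compound 3 (within the scatter). Compound 4 `O=C(/C(=C\c1ccc(F)cc1Cl)S(=O)(=O)c1ccc(Br)cc1)c1ccc(Br)cc1` differs from compound 3 by 2-chloro-4-fluorophenyl in place of 2-fluoro-4-methoxyphenyl on a double-bonded chain carbon bound to a double-bonded chain carbon. Among the compounds with values here, the steps that bear on it, from compound 1 to compound 2 and from compound 2 to compound 3, both swapped the group at this same place and both stayed within the scatter, so in this assay no step beyond the scatter is expected in either direction. Compound 4 is estimated at 8500 nM, range 4000 nM to 18000 nM, meaning an expected step of a 1.2-fold lower number from compound 3 to compound 4 (0.07 log units; within the scatter).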

Compound 4, concentration for 50% growth inhibition: 50000 nM
For compound 4 the middle estimate is 5.9-fold (0.77 log units) below the measured one; the whole stated range lies below it.
By their numbers in this assay, from the lowest: compounds 1, 2 and 3 (each within the scatter of the next); then compound 4.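

The aryl group on the double-bonded chain carbon is not indifferent in this assay: 2-chloro-4-fluorophenyl gives a 5.0-fold higher number from compound 3 to compound 4 (0.70 log units; beyond the scatter) and a 5.0-fold higher number from compound 2 to compound 4 (0.70 log units; beyond the scatter), both beyond the scatter, where the earlier swaps here were not. The change of narrowest scope, chloro in place of fluoro on an aromatic carbon, gives a 6.7-fold higher number from compound 1 to compound 4 (0.82 log units; beyond the scatter) and is enough to separate compound 4 from compound 1. Nothing available here accounts for this step.

As far as these compounds go, whether chloro has the same effect on other aryl groups at this place stays open. So does the reading of an amine or a carboxylic acid on this aryl group.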